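Swapping the sulfonyl heteroaryl group: compound 3 to compound 4

The source may hold more compounds than are shown below. What is called first, only, known or untested is meant among the compounds shown, and "the series" means these compounds.

Measured compounds:
- compound 1 `O=S(=O)(c1cnc2ccccc2c1)n1cc(C2=CCNCC2)c2cc(Cl)ccc21` gives 11 nM in an assay on HEK293 cells for displacement of a labelled ligand from 5-hydroxytryptamine receptor 6 (Homo sapiens), read by scintillation counting; on this read-out higher numbers stand for weaker inhibition and lower numbers for stronger inhibition
- compound 2 `O=S(=O)(c1cccc2ncccc12)n1cc(C2=CCNCC2)c2cc(Cl)ccc21` gives 11 nM in this assay
- compound 3 `COc1ccc2c(c1)c(C1=CCNCC1)cn2S(=O)(=O)c1cccc2ncccc12` gives 4 nM in this assay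

Compound 3 shows the lowest number of the three; compound 1 and compound 2 each sit a step beyond the scatter above it. Among the compounds with values here, the only measured step, a 2.8-fold lower number from compound 2 to compound 3 (0.44 log units; beyond the scatter), concerns the methoxy for chloro exchange, not the sulfonyl group. Compound 4 `COc1ccc2c(c1)c(C1=CCNCC1)cn2S(=O)(=O)c1cc2ccccc2cn1` carries isoquinolin-3-yl in place of quinolin-5-yl on a sulfonyl sulfur. Within the data shown here, no step for this change has been measured; compound 1 and compound 2, which differ only in their sulfonyl heteroaryl group, show the same value in this assay, so no step beyond the scatter is expected. Compound 4 is estimated at 5 nM (range 2 nM to 15 nM), that is an expected step of a 1.3-fold higher number from compound 3 to compound 4 (0.10 log units; within the scatter).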

Compound 4, inhibition constant: 6 nM
Compound 4: the middle estimate sits 1.2-fold (0.08 log units) below what was measured; the range from low to high includes it.
By their numbers in this assay, from the lowest: compounds 3, 4, 1 and 2 (each within the scatter of the next, the first and the last beyond it).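

Isoquinolin-3-yl in place of quinolin-5-yl on a sulfonyl sulfur gives a 1.5-fold higher number from compound 3 to compound 4 (0.18 log units; within the scatter) in this assay and so reads this exchange directly on the methoxy compounds. Earlier only the chloro pair spoke to the sulfonyl heteroaryl group, with compound 1 at 11 nM and compound 2 at 11 nM alike, so with chloro and with methoxy alike no exchange of this group moves the number beyond the scatter. No measurement at hand bears on the reason for this result.

Open, on these data alone, is whether a sulfonyl group without ring nitrogen, such as naphthyl or phenyl, holds the number in this range. Also open, as far as these compounds go, is whether isoquinolin-3-yl reads the same with chloro on the core.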